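A fluoro group on the benzyl of compound 3

A few compounds are considered here, and "the series" means these few. Any claim that something is new, unique, unknown or untested is made for them only; others in the source may bear on it.

Compound 1 `CN1CC2(CC(=O)c3cc(/C=C/C(=O)NO)ccc3O2)C1`: 168 nM
Compound 2 `CC(=O)N1CC2(CC(=O)c3cc(/C=C/C(=O)NO)ccc3O2)C1`: 15100 nM
Compound 3 `O=C(/C=C/c1ccc2c(c1)C(=O)CC1(CN(Cc3ccccc3)C1)O2)NO`: 175 nM

In a functional assay on K562 cells (Homo sapiens) for antiproliferative activity, read by luminescence, with a stated time of 72 h (a lower number here means a stronger inhibitor, a higher number a weaker inhibitor), compound 3 gives 175 nM. This is the middle of the three numbers, within the scatter of compound 1 and far from compound 2, with an 86-fold lower number from compound 2 to compound 3 (1.94 log units; beyond the scatter).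

The next compound is compound 4 `O=C(/C=C/c1ccc2c(c1)C(=O)CC1(CN(Cc3ccc(F)cc3)C1)O2)NO`. It differs from compound 3 by fluoro in place of hydrogen on an aromatic carbon, so that benzyl becomes 4-fluorobenzyl.

Going by the values given here, no measured step tests a fluoro group, so the evidence is indirect. On the amine nitrogen of the ring, going from methyl to benzyl gave a 1.0-fold higher number from compound 1 to compound 3 (0.02 log units; within the scatter), which lies within the scatter. The two large steps, a 90-fold higher number from compound 1 to compound 2 (1.95 log units; beyond the scatter) and an 86-fold lower number from compound 2 to compound 3 (1.94 log units; beyond the scatter), both involve the acetyl group, which compound 4 does not carry. Among the compounds with values here, compound 4 keeps the benzyl of compound 3 and adds only one small group at its far end, so no step beyond the scatter is expected in this assay, and no direction can be favoured.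

The expected step is a 1.1-fold lower number from compound 3 to compound 4 (0.04 log units; within the scatter). For compound 4 the estimated value is 160 nM, with an expected range from 75 nM to 340 nM.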

Compound 4, half-maximal inhibitory concentration: 301 nM
Compound 4: middle estimate off by 1.9-fold (0.27 log units), on the low side, and the stated range covers the measured number.
By their numbers in this assay, from the lowest: compounds 1, 3 and 4 (each within the scatter of the next); then compound 2.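

In this assay, going by these compounds alone, this is the first look at a substituent on the aromatic ring of the benzyl, and fluoro in place of hydrogen, para to a large group, gives a step that stays within the scatter (a 1.7-fold higher number from compound 3 to compound 4 (0.24 log units; within the scatter)), as does the comparison with the methyl compound (a 1.8-fold higher number from compound 1 to compound 4 (0.25 log units; within the scatter)). The large gap to the acetyl compound remains (a 50-fold lower number from compound 2 to compound 4 (1.70 log units; beyond the scatter)), so 4-fluorobenzyl on the amine nitrogen in the ring groups with benzyl and methyl, not with acetyl, among the four compounds shown. No measurement available here gives a reason for these numbers.

On these data alone, it remains open whether chloro, methoxy, trifluoromethyl or an amine in place of the fluoro would move the number beyond the scatter, and whether phenethyl in place of benzyl on the amine nitrogen would do so. As far as these compounds go, it is also open whether the large step belongs to acetyl alone or extends to other groups with a carbonyl on that nitrogen, such as benzoyl or a methyl carbamate.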